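Bromo-to-hydrogen step on the indole core, two pairs

This account rests on a few compounds, and the source may have more. Where it says the series, first, only, none or still open, it means among the compounds named here.

Working notes on a small series of indole hydrazide derivatives, all tested in a functional assay on MDA-MB-231 cells (Homo sapiens) for cytotoxicity; a higher number here means a weaker inhibitor, a lower number a stronger inhibitor. Compound 1 `COc1ccc(Cn2cc(/C=N\NC(=O)c3c[nH]c4ccc(Br)cc34)c3ccc(F)cc32)cc1` gives 99800 nM. Compound 2 `COc1ccc(Cn2cc(/C=N\NC(=O)c3c[nH]c4ccccc34)c3ccc(F)cc32)cc1` differs from compound 1 only by hydrogen in place of bromo on an aromatic carbon, and compound 2 gives 71200 nM. The resulting step is a 1.4-fold lower number from compound 1 to compound 2 (0.15 log units; within the scatter), so the removal of the bromo on the indole ring of the hydrazide part leaves the read-out essentially where it was.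

Compound 3 `O=C(N/N=C\c1cn(Cc2ccc(Cl)cc2)c2ccc(Br)cc12)c1c[nH]c2ccccc12` belongs to a different core; the difference between its core and the core of compound 1 is not broken down here. In this assay compound 3 gives 1000 nM, the lowest of the three numbers, and its gaps to compound 2 and compound 1 both lie beyond the scatter, so compound 3 is the most potent of the measured set.

Compound 4 `O=C(N/N=C\c1cn(Cc2ccc(Cl)cc2)c2ccccc12)c1c[nH]c2ccccc12` has not yet been measured. It is related to compound 3 by hydrogen in place of bromo on an aromatic carbon. The place of the change is described in the same words as for the pair compound 1 to compound 2, so this is the same change made on the other core. The expectation is that the step from compound 3 to compound 4 will be small, resting on the observation that a 1.4-fold lower number from compound 1 to compound 2 (0.15 log units; within the scatter) stayed within the scatter. The expected step is a 1.1-fold lower number from compound 3 to compound 4 (0.05 log units; within the scatter). Compound 4 is therefore estimated at 900 nM, with a likely range from 400 nM to 2200 nM.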

Compound 4, half-maximal inhibitory concentration: 66400 nM
The estimate for compound 4 lay 74-fold (1.87 log units) below the measured number; measured number above the stated range.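

Replacing bromo with hydrogen on the core of compound 3 in this assay gives a 66-fold higher number from compound 3 to compound 4 (1.82 log units; beyond the scatter), whereas the same change left the read-out essentially unmoved on the core of compound 1, and the two steps do not agree: the same change on two cores in this assay, a 1.4-fold lower number (0.15 log units; within the scatter) from compound 1 to compound 2 and a 66-fold higher number (1.82 log units; beyond the scatter) from compound 3 to compound 4, 93-fold (1.97 log units) apart, beyond the scatter of two such steps

For this series, the step measured on one core therefore cannot be carried over to the other, and the bromo matters on the core of compound 3 but shows no effect beyond the scatter on the core of compound 1. For the compounds shown here, with only two pairs, this does not show which of the several structural differences between the two cores separates the outcomes, nor does it give any reason for the large step, so it offers no rule for further cores.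

The compounds shown leave open whether the low number depends on bromo itself or whether another group at the same place, such as a methyl or a nitrile, would keep compound 3's potency of 1000 nM. They also leave open whether any group at that place on the core of compound 1 would move its number beyond the scatter.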